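This account rests on a few compounds, and the source may have more. Where it says the series, first, only, none or still open, it means among the compounds named here.

Measured in a functional assay on J774 cells (Mus musculus) for cytotoxicity, read by resazurin assay; a lower number here means a stronger inhibitor, a higher number a weaker inhibitor:

- Compound 1 `OCCCCCC(O)c1ccc(-c2ccc(Br)cc2)cc1`: 20000 nM
- Compound 2 `OCCCCCC(O)c1ccc(-c2ccccc2F)cc1`: 22000 nM
- Compound 3 `OCCCCCC(O)c1ccc(-c2ccc(F)cc2F)cc1`: 8000 nM

Compound 2 shares the upper end of these numbers with compound 1, and the gap between them is small: a 1.1-fold higher number from compound 1 to compound 2 (0.04 log units; within the scatter). Within the data shown here, that exchange of 2-fluorophenyl for 4-bromophenyl is the only measured step that replaces one substituted phenyl group with another. Compound 3 lies lower, and the step there is modest: a 2.8-fold lower number from compound 2 to compound 3 (0.44 log units; beyond the scatter). It comes from fluoro in place of hydrogen on an aromatic carbon.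

Compound 4 `Cc1cccc(-c2ccc(C(O)CCCCCO)cc2)c1` has not yet been measured. Its change from compound 2 is 3-methylphenyl in place of 2-fluorophenyl on an aromatic carbon. Among the measured compounds shown here, no measured step makes this exchange, and no compound in the set carries 3-methylphenyl, so the evidence is indirect. The closest guide is the step that stayed within the scatter, a 1.1-fold higher number from compound 1 to compound 2 (0.04 log units; within the scatter), while the step to compound 3 shows that a modest shift remains possible. No change beyond the scatter is therefore expected, and the estimated step is a 1.2-fold lower number from compound 2 to compound 4 (0.09 log units; within the scatter). For compound 4 the estimated value is 18000 nM, with an expected range from 8000 nM to 40000 nM.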

Compound 4, half-maximal inhibitory concentration: > 100000 nM
Compound 4: a limit, no number (the forecaster's own chance of this, stated with the estimate: 10%); at least 5.5-fold (0.74 log units) between middle value and limit.
By their numbers in this assay, from the lowest: compound 3; then compounds 1 and 2 (each within the scatter of the next). At a limit, above all of these: compound 4.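

In this assay compound 4 reads as a limit and not a number: the limit of > 100000 nM in this assay, at which 1 of the 4 values shown sits. Even so, the exchange on this aromatic carbon, para to a group of 8 heavy atoms, moves the result beyond the scatter, with an at least 4.5-fold higher number from compound 2 to compound 4 (0.65 log units; beyond the scatter) and an at least 5.0-fold higher number from compound 1 to compound 4 (0.69 log units; beyond the scatter). Among these compounds, the earlier exchange of 2-fluorophenyl for 4-bromophenyl had stayed within the scatter, so compound 4 is the first sign that the choice of substituted phenyl group at this place can matter in this assay, even though 3-methylphenyl and 2-fluorophenyl have the same count of 7 heavy atoms and neither has a hydrogen-bond donor or acceptor.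

The compounds shown leave open how far beyond the limit compound 4 lies, and whether the shift follows the methyl group itself or where it sits on the ring, which 2-methylphenyl and 3-fluorophenyl at the same place could help to separate. They also do not show how a phenyl group carrying an amine or a carboxylic acid would read in this assay.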